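The source may hold more compounds than are shown below. What is called first, only, known or untested is meant among the compounds shown, and "the series" means these compounds.

Measured compounds:

Compound 1 `N#Cc1cncc(N2CC[C@H]3CN[C@H]3C2)c1` — 1000 nM
Compound 2 `N#Cc1cncc(N2CC[C@@H]3CN[C@@H]3C2)c1` — 490 nM
Compound 3 `O=[N+]([O-])c1ccc(N2CC[C@@H]3CN[C@@H]3C2)cn1` — 830 nM

All three were tested in a functional assay on HEK293 cells for agonist activity at Neuronal acetylcholine receptor; alpha3/beta4 (Homo sapiens), read by FLIPR; a higher number here means that more compound is needed for the effect, a lower number that less compound is needed. Compound 2 has the lowest of the three numbers. Compound 3, with its nitro-bearing core, sits close by: its value and that of compound 2 lie within the usual scatter of each other, so no order between them can be claimed. Compound 1 is the mirror image of compound 2, and the step is a 2.0-fold lower number from compound 1 to compound 2 (0.31 log units; beyond the scatter); that comparison rests on (the fact that compounds 1 and 2 differ only in the configuration as drawn).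

Compound 4 `N/C(=N/O)c1cncc(N2CC[C@@H]3CN[C@@H]3C2)c1` is not yet measured. It differs from compound 2 in this way: a group of 4 heavy atoms (1 carbon, 2 nitrogen, 1 oxygen; no ring) in place of a group of 2 heavy atoms (1 carbon, 1 nitrogen; no ring), on an aromatic carbon. In words, a group of 4 heavy atoms (1 carbon, 2 nitrogen, 1 oxygen; no ring) replaces a group of 2 heavy atoms (1 carbon, 1 nitrogen; no ring), on an aromatic carbon. Within the data shown here, none of the measured steps touches this position; the only measured step concerns configuration alone, so it gives no guide to a change of substituent. With nothing to anchor a direction, the expected step is a 3.1-fold higher number from compound 2 to compound 4 (0.49 log units; beyond the scatter), carrying wide uncertainty. Compound 4 is estimated at 1500 nM, with a range from 350 nM to 7000 nM in this assay.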

Compound 4, half-maximal effective concentration: 5700 nM
Estimate against measurement, compound 4: 3.8-fold (0.58 log units) below, within the range that was stated.
By their numbers in this assay, from the lowest: compounds 2, 3 and 1 (each within the scatter of the next, the first and the last beyond it); then compound 4.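

Among these compounds, this is the first change at this place on the ring, two atoms from the ring nitrogen, and it shows that the position does not accept every replacement: exchanging cyano for the group of 4 heavy atoms, with the core and its configuration kept, gives a 12-fold higher number from compound 2 to compound 4 (1.07 log units; beyond the scatter). This step is clearly larger than the one between the mirror images, a 2.0-fold lower number from compound 1 to compound 2 (0.31 log units; beyond the scatter), so here the choice of substituent moves the number further than inverting the core does. What is known about these compounds offers no explanation for this rise.

One replacement cannot separate the part played by the extra heavy atoms from that of the hydrogen-bond donors. A primary amide, a carboxylic acid or a simple amine at the same carbon would show how far the trend extends.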